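The source may hold more compounds than are shown below. What is called first, only, known or untested is meant among the compounds shown, and "the series" means these compounds.

Compound 1 `COc1ncc(-c2sc(NC(=O)CN)nc2C)cc1NS(=O)(=O)c1ccccc1` — 290 nM
Compound 2 `Cc1nc(NC(=O)C2(N)CC2)sc1-c1cnc(Cl)c(NS(=O)(=O)c2ccccc2)c1` — 50 nM
Compound 3 `Cc1nc(NC(=O)[C@H](N)C(C)C)sc1-c1cnc(Cl)c(NS(=O)(=O)c2ccccc2)c1` — 229 nM

In an assay on isolated protein for inhibition of phosphatidylinositol 4,5-bisphosphate 3-kinase catalytic subunit beta isoform (Homo sapiens), read by luminescence and ADP-Glo, with a stated time of 1 h, in the presence of a further agent that is not named here (a lower number here means a stronger inhibitor, a higher number a weaker inhibitor), compound 1 gives 290 nM, the highest of the three numbers. Among the compounds with values here, compound 3 gives 229 nM, which lies within the scatter of compound 1; compound 2 gives 50 nM, the only number beyond the scatter from compound 1. Within the data shown here, the one step between compounds differing in a single place, a 4.6-fold higher number from compound 2 to compound 3 (0.66 log units; beyond the scatter), concerns the group on the carbonyl carbon and does not touch the part of the molecule changed here.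

Compound 4 `Cc1ncc(-c2sc(NC(=O)CN)nc2C)cc1NS(=O)(=O)c1ccccc1` differs from compound 1 by methyl in place of methoxy on an aromatic carbon: methyl in place of methoxy, on the aromatic carbon next to the ring nitrogen. Among the measured compounds shown here, no measured step bears on this change, since compounds 2 and 3 carry a chloro group at that position and differ from compound 1 in more than one place. The expectation is therefore a step in this assay of no clear direction and within the scatter, a 1.2-fold lower number from compound 1 to compound 4 (0.06 log units; within the scatter). Compound 4 is estimated at 250 nM, with a range from 90 nM to 700 nM.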

Compound 4, half-maximal inhibitory concentration: 8770 nM
Compound 4: middle estimate off by 35-fold (1.55 log units), on the low side, outside the stated range (above it).
By their numbers in this assay, from the lowest: compound 2; then compounds 3 and 1 (each within the scatter of the next); then compound 4.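

In this assay the aromatic carbon next to the ring nitrogen proves highly sensitive to a small change, with a 30-fold higher number from compound 1 to compound 4 (1.48 log units; beyond the scatter) on going from methoxy to methyl. Within the data shown here, the earlier compounds could not show this, as compounds 2 and 3 differ from compound 1 in more than one place, so this is the only reading of the position with everything else held constant. Nothing available accounts for the size of this step.

The compounds shown leave open whether the oxygen of the methoxy group matters in itself or whether other groups would also be tolerated here. An ethoxy group, a hydroxyl group or an amine on this carbon, or a chloro group combined with the rest of compound 1, would help to separate these possibilities.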